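The source may hold more compounds than are shown below. What is called first, only, known or untested is meant among the compounds shown, and "the series" means these compounds.

Of the compounds shown here, three built on a shared core have been measured. In a functional assay on HL-60 cells (Homo sapiens) for inhibition, read by MTT assay, with a stated time of 72 h (on this read-out higher numbers stand for weaker inhibition and lower numbers for stronger inhibition), compound 1 `Cc1nc(-c2ccccc2F)c(C(=O)N2CCN(c3cccc(Cl)c3)CC2)o1` gives 39.4 nM. Compound 2 `Cc1nc(-c2ccccc2)c(C(=O)N2CCN(c3ccccc3F)CC2)o1` gives 147 nM in this assay. Compound 3 `COc1cc(-c2nc(C)oc2C(=O)N2CCN(c3cccc(Cl)c3)CC2)ccc1O` gives 85.9 nM in this assay. Among these three numbers compound 3 holds the second highest; its nearest neighbour is compound 2, and those two lie within the usual scatter of each other, whereas the step of a 2.2-fold higher number from compound 1 to compound 3 (0.34 log units; beyond the scatter) lies beyond it.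

Compound 4 `Cc1nc(-c2ccccc2)c(C(=O)N2CCN(c3cccc(Cl)c3)CC2)o1` has not yet been measured in this assay. It differs from compound 3 in one place: phenyl in place of 4-hydroxy-3-methoxyphenyl on an aromatic carbon. Among the measured compounds shown here, the only measured step touching that same carbon is a 2.2-fold higher number from compound 1 to compound 3 (0.34 log units; beyond the scatter), in which the same 4-hydroxy-3-methoxyphenyl entered and the number rose modestly. In compound 4 that group leaves again in favour of a plain phenyl, so the change runs against the direction of that step. For the measured compounds named here, compound 2 also carries a phenyl on this carbon, but it differs from compound 4 elsewhere as well, so it gives no direct step. The expected outcome for compound 4 is therefore a modest fall in the number, estimated as a 1.7-fold lower number from compound 3 to compound 4 (0.24 log units; within the scatter). Compound 4 is expected to give about 50 nM in this assay, within a range from 20 nM to 130 nM.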

Compound 4, half-maximal inhibitory concentration: 39.2 nM
For compound 4 the middle estimate is 1.3-fold (0.11 log units) above the measured one; low and high end bracket the measured number.
By their numbers in this assay, from the lowest: compounds 4 and 1 (each within the scatter of the next); then compounds 3 and 2 (each within the scatter of the next).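

In this assay, with the 3-chlorophenyl kept on the ring nitrogen, taking away the substituted ring gives a 2.2-fold lower number from compound 3 to compound 4 (0.34 log units; beyond the scatter), while hydrogen for fluoro on the same aryl ring gives a 1.0-fold lower number from compound 1 to compound 4 (0.00 log units; within the scatter), so this carbon tolerates a plain phenyl and a 2-fluorophenyl alike, and of the three groups seen here, only the 4-hydroxy-3-methoxyphenyl gives a higher number. With phenyl fixed on this carbon, the other end of the molecule also counts, as 3-chlorophenyl in place of 2-fluorophenyl on the ring amine nitrogen gives a 3.8-fold lower number from compound 2 to compound 4 (0.57 log units; beyond the scatter). Nothing available explains why either change acts as it does.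

The compounds shown leave open whether the hydroxy group or the methoxy group on the phenyl accounts for the higher number, as none carries just one of the two. They also leave open how this carbon would respond to a group other than a substituted or plain phenyl, such as a methyl, a cyclohexyl or a phenyl bearing an amine or a carboxylic acid.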